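The source may report more compounds than this note shows. Statements on the series, on what has been measured and on what is new or still open speak of the compounds shown alone.

Measured compounds:
compound 1, `C[C@]1(c2ccc(O)cc2)CSc2cc(O)ccc2[C@H]1CCCCCCCCCC(CCCC(F)(F)C(F)(F)F)C(=O)O`: "not determined" (no result reported)
compound 2, `C[C@]1(c2ccc(O)cc2)CSc2cc(O)ccc2[C@H]1CCCCCCCCCC(CCCC(F)(F)C(F)(F)C(F)(F)C(F)(F)F)C(=O)O`: 100%

In a functional assay on the whole organism for antagonist activity, with Mus musculus as the target, at a dose of 30 mg/kg by the oral route (a lower number here means a weaker effect, a higher number a stronger effect of the compound at the dose given), compound 1 is recorded as "not determined" (no result reported), so on the numbers shown it stands nowhere: there is no figure to place it against. In this assay, among the compounds with values here, compound 2 gives 100%, and it is the only measured reference; no step between measured compounds exists. Compound 3, `C[C@]1(c2ccc(O)cc2)CSc2cc(O)ccc2[C@H]1CCCCCCCCCC(CCCCC(F)(F)C(F)(F)F)C(=O)O`, differs from compound 1 by a single change, (2,2,3,3,3-pentafluoropropyl in place of 1,1,2,2,2-pentafluoroethyl on a saturated chain carbon, four bonds along the chain from a carbonyl carbon). Since compound 1 carries no number, the step from compound 1 to compound 3 in this assay cannot be computed; the author expects a step of no size beyond the usual scatter, in neither direction, and regards compound 3 as lying close to its measured neighbour. Compound 3 is therefore expected to give about 80%, within a range from 40% to 100%, an estimate resting on compound 2 and its 100%.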

Compound 3, a percentage reported as inhibition, in the whole organism at one dose (the size of the read-out at that dose, not a potency): 96%
Compound 3: the middle estimate sits 16 percentage points below what was measured; measured number inside the range.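

Within the data shown here, no step from compound 1 to compound 3 can be read in this assay, where compound 1 stands as "not determined" (no result reported). The compounds shown leave open what the change from 1,1,2,2,2-pentafluoroethyl to 2,2,3,3,3-pentafluoropropyl does to this read-out. No evidence bears on the result.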